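The source may report more compounds than this note shows. Statements on the series, on what has been measured and on what is new or still open speak of the compounds shown alone.

Of the compounds shown here, three have been measured so far, all in an ADME assay on PC-3 cells (Homo sapiens) for cytotoxicity, read by WST assay, tested at 100 uM; on this read-out lower numbers stand for less inhibition and higher numbers for more inhibition at the one concentration tested (going by the name of the read-out). Compound 1 `COC(=O)c1cccc(NC(=O)C2CCCN(C(=O)c3cc(C(F)(F)F)cc(C(F)(F)F)c3)C2)c1` gives 0% in this assay. Compound 2 `COc1cccc(C(=O)N2CCCC(C(=O)Nc3ccc(Cl)cc3)C2)c1` gives 0%, and compound 3 `O=C(c1ccccc1)c1cccc(C(=O)N2CCCC(C(=O)Nc3ccc(Cl)cc3)C2)c1` gives 0%. Among the compounds with values here, the only step measured between compounds that differ in one place is no change at the digits printed from compound 2 to compound 3 (within the scatter), a change of benzoyl in place of methoxy on an aromatic carbon that left the read-out where it was. Within the data shown here, compound 1 therefore stands level with compounds 2 and 3, and no compound among the three shows any measurable cytotoxic effect at the concentration tested.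

The next compound is compound 4 `CC(C)(C)OC(=O)c1cccc(NC(=O)C2CCCN(C(=O)c3cc(C(F)(F)F)cc(C(F)(F)F)c3)C2)c1`. It differs from compound 1 by tert-butyl in place of methyl on an oxygen next to a carbonyl group. Among the measured compounds shown here, no measured step touches this ester position, so the one step that is known bears only indirectly on it: it shows that a change elsewhere on a related compound did nothing to the read-out. With every measured compound at the same flat level, and the change in compound 4 confined to the ester group, no step beyond the scatter is expected in this assay. The expected step is no change at the digits printed from compound 1 to compound 4 (within the scatter). Compound 4 is therefore estimated at 0%, with a range from -10% to 15%.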

Compound 4, a percentage reported as inhibition, at one concentration (the size of the read-out at that concentration, not a potency): 0%
Estimate against measurement, compound 4: no gap at the digits printed, within the range that was stated.
By their numbers in this assay, from the lowest: compounds 1, 2, 3 and 4 (each within the scatter of the next).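

In this assay the ester group now has a measured step of its own: no change at the digits printed from compound 1 to compound 4 (within the scatter), with tert-butyl in place of methyl on an oxygen next to a carbonyl group. Within the data shown here, the only earlier step concerned a different place on a different pair of compounds, so this is the first sign that methoxycarbonyl can grow to tert-butoxycarbonyl, from 1 heavy atom to 4 heavy atoms in the group that changes, without moving this read-out. Nothing available offers an explanation for this result.

All the compounds shown read alike in this assay, so this step cannot tell how the same change would behave on a compound with a measurable effect in that assay. It also remains open whether a carboxylic acid, an amide or an amine in place of the methoxycarbonyl group would leave the read-out where it is, since both esters shown keep the same carbonyl and oxygen and differ only in the group on that oxygen.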